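Replacing the phenyl of compound 3: what to expect

The compounds below may be only part of what the source reports. "The series", "measured", "known", "first", "only" and "open" are said of these compounds alone.

- compound 1 `COc1cc2ncnc(-n3nc(-c4ccccn4)nc3N)c2cc1N`: 3000 nM
- compound 2 `COc1cc2ncnc(-n3nc(N)nc3N)c2cc1OC`: 83000 nM
- compound 3 `COc1cc2ncnc(-n3nc(-c4ccccn4)nc3N)c2cc1OCc1ccccc1`: 58000 nM

All three values come from a physicochemical assay for solubility, in phosphate buffer, with a stated time of 18 h, at pH 7.4; on this read-out lower numbers stand for lower solubility and higher numbers for higher solubility. Compound 3, at 58000 nM, lies within the usual scatter of compound 2 and far from compound 1.

Compound 4 `COc1cc2ncnc(-n3nc(-c4ccccn4)nc3N)c2cc1OCCCN1CC(C)OC(C)C1` has not yet been measured. It differs from compound 3 as follows: 2-(2,6-dimethylmorpholin-4-yl)ethyl in place of phenyl on a saturated chain carbon bound to an oxygen on an aromatic ring. In short, 2-(2,6-dimethylmorpholin-4-yl)ethyl replaces phenyl, so benzyloxy becomes 3-(2,6-dimethylmorpholin-4-yl)propoxy.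

For the measured compounds named here, only one measured step touches this group: a 19-fold higher number from compound 1 to compound 3 (1.29 log units; beyond the scatter), a large step with benzyloxy in place of amino on an aromatic carbon. It shows that a change here can move the number a long way, but it involves a different replacement and gives no direct size or direction for this one. No step beyond the scatter is therefore expected, with only a slight upward lean, and the range stays wide. The expected change is a 1.4-fold higher number from compound 3 to compound 4 (0.14 log units; within the scatter) and remains uncertain. For compound 4 the estimated value is 80000 nM, expected to fall between 25000 nM and 250000 nM.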

Compound 4, solubility: 8000 nM
Estimate against measurement, compound 4: 10-fold (1.00 log units) above; the whole stated range lies above it.
By their numbers in this assay, from the lowest: compound 1; then compound 4; then compounds 3 and 2 (each within the scatter of the next).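

For the compounds shown here, the group at the end of this chain matters in its own right: with 2-(2,6-dimethylmorpholin-4-yl)ethyl in place of phenyl, this assay gives a 7.3-fold lower number from compound 3 to compound 4 (0.86 log units; beyond the scatter) and not the near-level result that the earlier compounds left possible. Measured against amino, the 3-(2,6-dimethylmorpholin-4-yl)propoxy group still gives a 2.7-fold higher number from compound 1 to compound 4 (0.43 log units; beyond the scatter) as a step in the same direction, yet a smaller one than a 19-fold higher number from compound 1 to compound 3 (1.29 log units; beyond the scatter) for benzyloxy, so the two groups do not count as interchangeable here. Nothing in the data shown accounts for this difference.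

The dimethylmorpholine ring and the propyl chain enter together in this step, and the compounds shown do not separate them. A piperidine or a dimethylamino group on the same propoxy chain would help to tell which of the two carries the change.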